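The source may report more compounds than this note shows. Statements on the series, on what has been measured and on what is new or still open speak of the compounds shown alone.

Of the compounds shown here, three share one core and have been measured in a functional assay on the whole organism (strain NMRI) with Mus musculus as the target, with a stated time of 60 min, at a dose of 5 mg/kg by the intraperitoneal route; a higher number here means a stronger effect of the compound at the dose given, a lower number a weaker effect. Compound 1, `CSc1nnc(Cc2ccc(Cl)cc2Oc2ccccc2Cl)[nH]1`, gives 125% in this assay. Compound 2, `CCSc1nnc(Cc2ccc(Cl)cc2Oc2ccccc2Cl)[nH]1`, gives 134% in this assay. Compound 3, `CSc1nnc(Cc2ccc(Cl)cc2Oc2ccccc2F)[nH]1`, gives 110% in this assay, the lowest of the three numbers; its nearest neighbour is compound 1, and that gap is the step of a number 15 percentage points lower from compound 1 to compound 3 (beyond the scatter), while compound 2 lies furthest from it. Compound 4, `CCSc1nnc(Cc2ccc(Cl)cc2Oc2ccccc2F)[nH]1`, has not yet been measured. It differs from compound 3 in one place: methyl in place of hydrogen on a saturated chain carbon bound to a sulfur. The same change has been seen once before, in the step of a number 9 percentage points higher from compound 1 to compound 2 (within the scatter), which stayed within the scatter. On that single precedent the change is expected to move the number only a little, a number 6 percentage points higher from compound 3 to compound 4 (within the scatter), with no direction that can be trusted beyond the scatter. Compound 4 is therefore estimated at 116% in this assay, with a range from 96% to 138%.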

Compound 4, a percentage reported as activity, at one dose (the size of the read-out at that dose, not a potency): 126%
Estimate against measurement, compound 4: 10 percentage points below, within the range that was stated.
By their numbers in this assay, from the lowest: compound 3; then compounds 1, 4 and 2 (each within the scatter of the next).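

In this assay, methyl in place of hydrogen on a saturated chain carbon bound to a sulfur gives a number 16 percentage points higher from compound 3 to compound 4 (beyond the scatter), so the change from methylsulfanyl to ethylsulfanyl now clears the scatter, which its first reading did not, yet the two readings cannot be told apart: the same change on two cores in this assay, a number 9 percentage points higher (within the scatter) from compound 1 to compound 2 and a number 16 percentage points higher (beyond the scatter) from compound 3 to compound 4, 7 percentage points apart, within the scatter of two such steps. Fluoro in place of chloro on an aromatic carbon gives a number 8 percentage points lower from compound 2 to compound 4 (within the scatter), so this change does not clear the scatter here, though it did at its first reading, and again the two readings cannot be told apart: the same change on two cores in this assay, a number 15 percentage points lower (beyond the scatter) from compound 1 to compound 3 and a number 8 percentage points lower (within the scatter) from compound 2 to compound 4, 7 percentage points apart, within the scatter of two such steps. Each change keeps its direction on both cores, with one step beyond the scatter and one within it.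

The compounds shown carry only methylsulfanyl or ethylsulfanyl and only chloro or fluoro, so a longer chain such as propyl, or bromo in place of the halogen, remains open. All the readings come from a single dose, so they speak only of a stronger or weaker effect at that dose.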